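The compounds below may be only part of what the source reports. "The series", "measured", "known", "first", "only" and "open" are said of these compounds alone.

Measured so far in an assay on CHO-K1 cells for antagonist activity at adenosine receptor A1 (Homo sapiens), read by a beta-galactosidase reporter, with stated times of 15 min and 6 h; on this read-out lower numbers stand for stronger inhibition and higher numbers for weaker inhibition:
compound 1 `Nc1nc(-c2ccc(Cl)o2)nc2sc(CN3CC=CC3)cc12` — 780 nM
compound 2 `N#Cc1cccc(-c2nc(N)c3cc(CN4CC=CC4)sc3n2)c1` — 2070 nM

For the measured compounds named here, compound 2 carries the higher of the two numbers in this assay; its nearest neighbour is compound 1, and the one step that connects them, a 2.7-fold higher number from compound 1 to compound 2 (0.42 log units; beyond the scatter), exchanges the whole aryl group on the shared core. Compound 3 `N#Cc1ccc(-c2nc(N)c3cc(CN4CC=CC4)sc3n2)cc1` keeps that core and the same atoms as compound 2, differing only in how they are joined: 4-cyanophenyl in place of 3-cyanophenyl on an aromatic carbon. Going by the values given here, no measured pair shows the effect of shifting the nitrile within the phenyl ring, so the step from compound 1 to compound 2 bears on it only indirectly, as a sign that the aryl group is a region where changes register in this assay at a modest size. Among the compounds with values here, with no direct precedent, the step from compound 2 to compound 3 is expected to be small, in either direction, most likely within the scatter: a 1.2-fold higher number from compound 2 to compound 3 (0.08 log units; within the scatter). Compound 3 is therefore estimated at 2500 nM, with a range from 900 nM to 7000 nM.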

Compound 3, inhibition constant: 2350 nM
For compound 3 the middle estimate is 1.1-fold (0.03 log units) above the measured one, within the range that was stated.
By their numbers in this assay, from the lowest: compound 1; then compounds 2 and 3 (each within the scatter of the next).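

In this assay the move of the nitrile within the phenyl ring registers as a 1.1-fold higher number from compound 2 to compound 3 (0.06 log units; within the scatter) and so leaves 3-cyanophenyl and 4-cyanophenyl on this aromatic carbon indistinguishable on this read-out. The gap to the 5-chlorofuran-2-yl group of compound 1 also holds for the second cyanophenyl isomer, at a 3.0-fold higher number from compound 1 to compound 3 (0.48 log units; beyond the scatter) and therefore belongs to both cyanophenyl compounds rather than to a single placement of the nitrile. Nothing available explains either the lack of separation between the two isomers or their gap to compound 1.

Still open is whether the nitrile contributes at all, since the compounds shown offer no comparison with an unsubstituted phenyl or with a carboxylic acid or primary amide in the nitrile's place. Also open, on these data alone, is how much of the number of compound 1 depends on the chlorine of the furan, which a plain furan-2-yl or a 5-methylfuran-2-yl group on the shared core would address.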